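The source may hold more compounds than are shown below. What is called first, only, known or untested is meant among the compounds shown, and "the series" means these compounds.

Measured so far in a functional assay on HCT-116 cells (Homo sapiens) for antiproliferative activity, read by MTT assay, with a stated time of 48 h; on this read-out lower numbers stand for stronger inhibition and higher numbers for weaker inhibition:
compound 1, `COc1ccc(N(C)c2ccnc(Cl)n2)cc1F`, gives 914 nM;
compound 2, `COc1ccc(N(C)c2ccnc(Cl)n2)cc1Cl`, gives 1170 nM;
compound 3, `COc1ccc(N(C)c2cc(C)nc(C)n2)cc1F`, gives 584 nM.

Compound 2 differs from compound 1 by chloro in place of fluoro on an aromatic carbon, and the step it made was a 1.3-fold higher number from compound 1 to compound 2 (0.11 log units; within the scatter). Compound 3 carries a different core from compound 1; the difference between the two cores is not broken down here. Its number in this assay is close to that of compound 1, and the gap between compound 3 and compound 2 is also within the scatter, so no order among the three can be drawn.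

Compound 4, `COc1ccc(N(C)c2cc(C)nc(C)n2)cc1Cl`, has not yet been measured. It differs from compound 3 by chloro in place of fluoro on an aromatic carbon. Among the measured compounds shown here, this is the same kind of change as the one from compound 1 to compound 2: in both the place is ortho to a methoxy group, but in the first case it is meta to a group of 9 heavy atoms and here meta to a large group. Because the step of a 1.3-fold higher number from compound 1 to compound 2 (0.11 log units; within the scatter) stayed within the scatter, a similar small shift is expected for compound 4, namely a 1.3-fold higher number from compound 3 to compound 4 (0.11 log units; within the scatter). The number estimated for compound 4 in this assay is therefore 750 nM, expected to lie between 400 nM and 1400 nM.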

Compound 4, half-maximal inhibitory concentration: 1190 nM
For compound 4 the middle estimate is 1.6-fold (0.20 log units) below the measured one, and the stated range covers the measured number.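

In this assay, chloro in place of fluoro on an aromatic carbon gave a 2.0-fold higher number from compound 3 to compound 4 (0.31 log units; beyond the scatter), a modest step that passes the usual scatter, whereas the same change on the other core gave a 1.3-fold higher number from compound 1 to compound 2 (0.11 log units; within the scatter), which stays within it. Even so, the two steps cannot be told apart, so these pairs give no sign that the result of the change depends on the core: the same change on two cores in this assay, a 1.3-fold higher number (0.11 log units; within the scatter) from compound 1 to compound 2 and a 2.0-fold higher number (0.31 log units; beyond the scatter) from compound 3 to compound 4, 1.6-fold (0.20 log units) apart, within the scatter of two such steps This does not show that the core of compound 3 responds more strongly than the core of compound 1, and two pairs cannot show that the change would carry over in the same way to any further core.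

The compounds shown leave open how other groups at this place, such as bromo, methyl or a nitrile, would read on either core. They also leave open what would follow if an ethoxy group, a hydroxyl group or an amine stood in place of the methoxy group.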